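Adding a methoxy to compound 2: expected outcome

This account rests on a few compounds, and the source may have more. Where it says the series, first, only, none or still open, it means among the compounds named here.

Of the compounds shown here, three have been tested in a functional assay on MCF7 cells (Homo sapiens) for cytotoxicity, read by MTT assay, with a stated time of 24 h; a lower number here means a stronger inhibitor, a higher number a weaker inhibitor. Compound 1, `COc1cc(C2=C(O)C(=O)c3cc(OC)c(OC)c(OC)c32)cc(OC)c1OC`, returns only a limit in this assay, >= 250000 nM. Compound 2, `COc1cc2c(cc1OC)C(c1cc(OC)c(OC)c(OC)c1)CC2=O`, likewise returns only a limit, >= 250000 nM. Compound 3, `COc1cc2c(c(OC)c1OC)C(c1ccccc1)CC2=O`, also gives a limit, >= 250000 nM. Compound 2 therefore stands where the whole measured set stands, at the limit of >= 250000 nM in this assay, at which 3 of the 3 values shown sit, and none of the three results is a number that can be ranked against another.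

Compound 4, `COc1cc(C2CC(=O)c3cc(OC)c(OC)c(OC)c32)cc(OC)c1OC`, is not yet measured. Relative to compound 2 the difference is methoxy in place of hydrogen on an aromatic carbon. Among the compounds with values here, no step between measured compounds is available, so the size of this change cannot be read from the series itself. Given that compound 2 sits at the limit of >= 250000 nM in this assay, at which 3 of the 3 values shown sit, the expected change is a number no higher from compound 2 to compound 4 (the limit leaves the size open), that is, none beyond the scatter, with the most likely result being another limit. The estimate for compound 4 in this assay is 250000 nM, in the range 100000 nM to 500000 nM, and the result is expected to be reported as a limit rather than as a number.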

Compound 4, half-maximal inhibitory concentration: 2200 nM
For compound 4 the middle estimate is 110-fold (2.06 log units) above the measured one, outside the stated range (below it).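

In this assay, a single methoxy in place of hydrogen turns a compound that reads only as a limit into one with a measured number, an at least 110-fold lower number from compound 2 to compound 4 (2.05 log units; beyond the scatter). The change sits on an aromatic carbon of a six-membered aromatic ring of carbon only, part of a fused or bridged system of two rings, ortho to a methoxy group and meta to a methoxy group, so this one place on the shared core proves decisive for the read-out. The earlier compounds shown here could not show this, since none of them gave a number that could be ranked, and compound 4 now stands alone as the reference point of the set: the limit of >= 250000 nM in this assay, at which 3 of the 4 values shown sit.

On these data alone, one end of the step is a limit, so its true size stays open, and steps among compound 1, compound 2 and compound 3 cannot be read. The compounds shown do not tell whether the gain belongs to methoxy itself or would also follow from another group on this carbon, such as an amine, a fluorine atom or a longer chain like ethoxy.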